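A few compounds are considered here, and "the series" means these few. Any claim that something is new, unique, unknown or untested is made for them only; others in the source may bear on it.

In a functional assay on MCF7 cells (Homo sapiens) for inhibition, read by MTT assay, with a stated time of 72 h (on this read-out higher numbers stand for weaker inhibition and lower numbers for stronger inhibition), compound 1 `CN(C(=O)NC(=O)c1ccccc1F)c1nc(C(F)(F)F)c(C(=O)N/N=C/c2ccc(C(F)(F)F)cc2)s1` gives 4.98 ug/mL and compound 2 `CN(C(=O)NC(=O)c1ccc(Cl)cc1Cl)c1nc(C(F)(F)F)c(C(=O)N/N=C/c2ccc(C(F)(F)F)cc2)s1` gives 8.42 ug/mL, while compound 3 `CN(C(=O)NC(=O)c1ccc(F)c(F)c1)c1nc(C(F)(F)F)c(C(=O)N/N=C/c2ccc([N+](=O)[O-])cc2)s1` gives 4.81 ug/mL, the smallest of the three numbers, though its gaps to both others sit within the scatter. Among the measured compounds shown here, the only single-point step, a 1.7-fold higher number from compound 1 to compound 2 (0.23 log units; within the scatter), concerns the group on the carbonyl carbon and also stays within the scatter. Compound 4 `CN(C(=O)NC(=O)c1ccc(F)c(F)c1)c1nc(C(F)(F)F)c(C(=O)N/N=C/c2ccc(C(F)(F)F)cc2)s1` differs from compound 3 at another place: trifluoromethyl in place of nitro on an aromatic carbon. For the measured compounds named here, no measured step alters this position on its own; compounds 1 and 3, which differ here and at the carbonyl carbon, show nearly identical values. The change is therefore expected to bring no step beyond the scatter, with a 1.0-fold higher number from compound 3 to compound 4 (0.02 log units; within the scatter). Compound 4 is estimated at 5 ug/mL, between 2.5 ug/mL and 10 ug/mL.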

Compound 4, half-maximal inhibitory concentration: 5.93 ug/mL
Estimate against measurement, compound 4: 1.2-fold (0.07 log units) below, within the range that was stated.
By their numbers in this assay, from the lowest: compounds 3, 1, 4 and 2 (each within the scatter of the next).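

Among the compounds shown here, compound 3 and compound 4 give the first direct reading of this position in this assay: trifluoromethyl in place of nitro brings a 1.2-fold higher number from compound 3 to compound 4 (0.09 log units; within the scatter) and so leaves the read-out within the scatter. With 3,4-difluorophenyl on the carbonyl carbon, the steps of a 1.4-fold lower number from compound 2 to compound 4 (0.15 log units; within the scatter) and a 1.2-fold higher number from compound 1 to compound 4 (0.08 log units; within the scatter) also stay within the scatter, so neither group change separates these compounds. Nothing available here explains these steps. What an amine, a carboxylic acid or a longer chain would give at this place remains open, since only nitro and trifluoromethyl are shown there.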